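This account rests on a few compounds, and the source may have more. Where it says the series, first, only, none or still open, it means among the compounds named here.

Of the compounds shown here, three with a shared core have been measured in an assay on isolated protein for inhibition of seed linoleate 13S-lipoxygenase-1 (Glycine max); a lower number here means a stronger inhibitor, a higher number a weaker inhibitor. Compound 1 `CCCCCN(CCCCC)Cc1c(O)ccc2ccc(=O)oc12` gives 13000 nM. Compound 2 `O=c1ccc2ccc(O)c(CNCc3ccccc3)c2o1` gives 44000 nM. Compound 3 `CCNCc1c(O)ccc2ccc(=O)oc12` gives 52000 nM. Among these three numbers compound 2 stands second highest: its nearest neighbour is compound 3, and the two lie within the scatter of each other, while compound 1 sits furthest away with a number well beyond the scatter.

Compound 4 `NCCNCc1c(O)ccc2ccc(=O)oc12` has not yet been measured in this assay. It differs from compound 2 in one place: aminomethyl in place of phenyl on a saturated chain carbon bound to an amine nitrogen. For the measured compounds named here, one measured step bears on this change, the one from compound 2 to compound 3, where the same phenyl left the same carbon and a methyl took its place; that step was a 1.2-fold higher number from compound 2 to compound 3 (0.07 log units; within the scatter), within the scatter. Replacing phenyl with a group of similar small size is therefore expected to give at most a small step in this assay, with no clear direction beyond the scatter, and the estimate for compound 4 is 45000 nM with a range from 15000 nM to 140000 nM, corresponding to a 1.0-fold higher number from compound 2 to compound 4 (0.01 log units; within the scatter).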

Compound 4, half-maximal inhibitory concentration: >> 1000000 nM
Compound 4 was reported as a limit; the forecaster's own chance of this, stated with the estimate: 15%; middle value at least 22-fold (1.34 log units) from the limit.
By their numbers in this assay, from the lowest: compound 1; then compounds 2 and 3 (each within the scatter of the next). At a limit, above all of these: compound 4.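

In this assay, the group on this saturated chain carbon is not free to change: replacing phenyl with aminomethyl gives an at least 22-fold higher number from compound 2 to compound 4 (1.35 log units; beyond the scatter), whereas the step to methyl stayed within the scatter. The closest comparison adds only an amino group on a saturated chain carbon, two bonds along the chain from an amine nitrogen, and gives an at least 19-fold higher number from compound 3 to compound 4 (1.28 log units; beyond the scatter), so the large step here goes with that amino group and not simply with the loss of phenyl. Compound 4 is reported as a limit of the assay, not as a number: the limit of >> 1000000 nM in this assay, at which 1 of the 4 values shown sits.

The compounds shown leave open whether a hydroxyl in place of this amino group would bring the same large step. They also leave open whether a dimethylamino group or a longer chain carrying the amine would do so.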